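Fluorophenyl Urea to Dichlorophenyl Urea on One Core

This account rests on a few compounds, and the source may have more. Where it says the series, first, only, none or still open, it means among the compounds named here.

Compound 1 `CNC(=O)c1cc(Oc2ccc3nc(NC(=O)c4ccc(Cl)cc4)sc3c2)ccn1`: 80.5%
Compound 2 `CNC(=O)c1cc(Oc2ccc3nc(NC(=O)Nc4ccc(F)cc4)sc3c2)ccn1`: 83.8%

In a functional assay on HCT-116 cells (Homo sapiens) for inhibition, read by MTT assay, with a stated time of 2 days, tested at 100 uM (on this read-out higher numbers stand for more inhibition of growth at the one concentration tested and lower numbers for less inhibition of growth), compound 2 gives 83.8% and compound 1 gives 80.5%; the two stand together, since the step of a number 3.3 percentage points higher from compound 1 to compound 2 (within the scatter) is within the scatter. Compound 3 `CNC(=O)c1cc(Oc2ccc3nc(NC(=O)Nc4ccc(Cl)cc4Cl)sc3c2)ccn1` differs from compound 2 by 2,4-dichlorophenyl in place of 4-fluorophenyl on an amide-type nitrogen. Within the data shown here, the single measured step alters both the carbonyl neighbour and the halogen, so it bears on this change only loosely, yet it shows that halogenated phenyl groups in this part of the molecule give similar growth inhibition. A step of a number 3.8 percentage points lower from compound 2 to compound 3 (within the scatter) is therefore expected, none beyond the scatter. Compound 3 is estimated at 80%, within 65% to 92%.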

Compound 3, percent growth inhibition at one concentration: 93.6%
Compound 3: the middle estimate sits 13.6 percentage points below what was measured; the whole stated range lies below it.
By their numbers in this assay, from the lowest: compounds 1, 2 and 3 (each within the scatter of the next, the first and the last beyond it).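

In this assay the change from 4-fluorophenyl to 2,4-dichlorophenyl on the amide-type nitrogen gives a number 9.8 percentage points higher from compound 2 to compound 3 (within the scatter) and so leaves the read-out within the scatter. Among these compounds, the step of a number 13.1 percentage points higher from compound 1 to compound 3 (beyond the scatter) is modest but is the first here to pass the scatter, and in it the group on the carbonyl carbon changes. Nothing given here explains either step. Open, as far as these compounds go, is how an amine or a carboxylic acid would read at this position on the amide-type nitrogen.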